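Aryl substituent series: methoxy to methyl swap

This account rests on a few compounds, and the source may have more. Where it says the series, first, only, none or still open, it means among the compounds named here.

In an assay on CHO cells for displacement of a labelled ligand from adenosine receptor A1 (Homo sapiens), read by scintillation counting, with a stated time of 3 h (on this read-out lower numbers stand for stronger inhibition and higher numbers for weaker inhibition), compound 2 `COc1ccc(-c2nc3c(NC4CCCC4)ncnc3n2C)cc1` gives 75 nM, the highest of the three numbers recorded. Compound 1 `Cn1c(-c2cccc(Cl)c2)nc2c(NC3CCCC3)ncnc21` gives 6.5 nM in this assay, and compound 3 `CCCn1c(-c2ccccc2)nc2c(NC3CCCCC3)ncnc21` gives 27 nM. Within the data shown here, the one single-point step recorded, a 12-fold higher number from compound 1 to compound 2 (1.06 log units; beyond the scatter), shows that the group on the aryl ring moves the number strongly. Compound 3 differs from compound 2 in more than one place, so its value only shows that a plain phenyl analogue sits lower than compound 2.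

Compound 4 `Cc1ccc(-c2nc3c(NC4CCCC4)ncnc3n2C)cc1` differs from compound 2 by methyl in place of methoxy on an aromatic carbon. Among the measured compounds shown here, no measured step covers a methoxy-to-methyl exchange at this position, so the direction is open. The large step from compound 1 to compound 2 argues that changes here can be large, but the change to compound 4 is smaller than that one. A modest step toward a lower number is expected for compound 4, estimated at 45 nM in this assay, within 15 nM to 140 nM. The step this estimate implies is a 1.7-fold lower number from compound 2 to compound 4 (0.22 log units; within the scatter), and it is expected to sit near the edge of the scatter.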

Compound 4, inhibition constant: 8 nM
The estimate for compound 4 lay 5.6-fold (0.75 log units) above the measured number; measured number outside the range, below it.
By their numbers in this assay, from the lowest: compounds 1 and 4 (each within the scatter of the next); then compound 3; then compound 2.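

In this assay, exchanging methoxy for methyl at this aryl position gives a 9.4-fold lower number from compound 2 to compound 4 (0.97 log units; beyond the scatter), so a single small change on the 4-substituted phenyl ring moves the number beyond the scatter. The reading for the other new pair, a 1.2-fold higher number from compound 1 to compound 4 (0.09 log units; within the scatter), puts the 4-methylphenyl and 3-chlorophenyl groups within the scatter of each other. A 4-substituted phenyl ring is therefore not tied to a high number on this core, and the high number of compound 2 goes with the 4-methoxyphenyl group in this small set. Nothing available explains the gap between methoxy and methyl.

From the compounds shown here alone, it remains open whether a hydroxyl, an ethyl or a dimethylamino group here would group with methyl or with methoxy. Going by these compounds, it is also open whether the methoxy-to-methyl step carries over to the propyl and cyclohexyl groups of compound 3.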